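Working Notes: Benzyl Ether Swap Across Two Core Pairs

The source may report more compounds than this note shows. Statements on the series, on what has been measured and on what is new or still open speak of the compounds shown alone.

Measured compounds in a functional assay on MNK45 cells (Homo sapiens) for inhibition, read by MTT assay, with a stated time of 48 h; on this read-out higher numbers stand for weaker inhibition and lower numbers for stronger inhibition:
- compound 1 `Cc1ccc(NC(=S)NC(=O)c2ccc(OCc3ccccc3F)cc2)cc1-c1nc2ccccc2[nH]1` gives 2420 nM
- compound 2 `Cc1ccc(COc2ccc(C(=O)NC(=S)Nc3ccc(C)c(-c4nc5ccccc5[nH]4)c3)cc2)cc1` gives 11300 nM
- compound 3 `O=C(NC(=O)c1ccc(OCc2ccccc2F)cc1)Nc1ccc(Cl)c(-c2nc3ccccc3[nH]2)c1` gives 870 nM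

Compound 1 and compound 2 share one core and differ only by 4-methylphenyl in place of 2-fluorophenyl on a saturated chain carbon bound to an oxygen on an aromatic ring; that change produced a 4.7-fold higher number from compound 1 to compound 2 (0.67 log units; beyond the scatter). Compound 3 carries a second core; the difference between the two cores is not broken down here. In this assay compound 3 has the lowest number of the three.

Compound 4 `Cc1ccc(COc2ccc(C(=O)NC(=O)Nc3ccc(Cl)c(-c4nc5ccccc5[nH]4)c3)cc2)cc1` is not yet measured. It differs from compound 3 by 4-methylphenyl in place of 2-fluorophenyl on a saturated chain carbon bound to an oxygen on an aromatic ring, the same change that was made on the first core. A step of similar size is expected, a 4.4-fold higher number from compound 3 to compound 4 (0.64 log units; beyond the scatter), because the same change on the first core gave a 4.7-fold higher number from compound 1 to compound 2 (0.67 log units; beyond the scatter). Compound 4 is therefore estimated at 3800 nM in this assay, with a range from 1500 nM to 9500 nM.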

Compound 4, half-maximal inhibitory concentration: 3190 nM
Estimate against measurement, compound 4: 1.2-fold (0.08 log units) above, within the range that was stated.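

In this assay, 4-methylphenyl in place of 2-fluorophenyl gives a 3.7-fold higher number from compound 3 to compound 4 (0.56 log units; beyond the scatter), and the size of the step holds from one core to the other: the same change on two cores in this assay, a 4.7-fold higher number (0.67 log units; beyond the scatter) from compound 1 to compound 2 and a 3.7-fold higher number (0.56 log units; beyond the scatter) from compound 3 to compound 4, 1.3-fold (0.10 log units) apart, within the scatter of two such steps. On these two cores the change therefore acts in the same direction and to a similar extent. This does not show that the step would hold on any further core, and two pairs cannot say whether it comes from losing 2-fluorophenyl or from gaining 4-methylphenyl.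

From the compounds shown here alone, it remains open whether the step persists when an amine or a carboxylic acid sits on that aryl ring, or when a longer chain replaces the single saturated carbon. The compounds shown also leave the difference between the two cores unresolved.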